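Swapping bromo for nitro on a cytotoxicity series

This account rests on a few compounds, and the source may have more. Where it says the series, first, only, none or still open, it means among the compounds named here.

Compound 1 `O=C(NNC(=O)c1ccc([N+](=O)[O-])cc1)c1ccc(-n2cccc2)cc1` and compound 2 `O=C(NNC(=O)c1ccc(-n2cccc2)cc1)c1ccc(Br)cc1` share one core; compound 3 `Brc1ccc(-c2nnc(-c3ccc(-n4cccc4)cc3)o2)cc1` and compound 4 `O=[N+]([O-])c1ccc(-c2nnc(-c3ccc(-n4cccc4)cc3)o2)cc1` share another, and the difference between the two cores is not broken down here. In an ADME assay on A549 cells (Homo sapiens) for cytotoxicity, read by MTT assay, with a stated time of 72 h (on this read-out higher numbers stand for weaker inhibition and lower numbers for stronger inhibition), compound 1 gives 198000 nM, compound 2 gives 201000 nM, and compound 3 gives 264000 nM. The change nitro in place of bromo on an aromatic carbon produced a 1.0-fold lower number from compound 2 to compound 1 (0.01 log units; within the scatter). The same change, (nitro in place of bromo on an aromatic carbon), turns compound 3 into compound 4. Since the earlier step from compound 2 to compound 1 stayed flat, compound 4 is expected to sit close to compound 3, with an estimated step of a 1.0-fold lower number from compound 3 to compound 4 (0.01 log units; within the scatter). Compound 4 is therefore estimated at 260000 nM, with the likely range running from 130000 nM to 520000 nM.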

Compound 4, half-maximal inhibitory concentration: 258000 nM
For compound 4 the middle estimate is 1.0-fold (0.00 log units) above the measured one; low and high end bracket the measured number.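

In this assay, nitro in place of bromo gives a 1.0-fold lower number from compound 3 to compound 4 (0.01 log units; within the scatter), so this swap stays flat on the second core as well. Set beside the earlier step, the change carries over from one core to the other with no difference that can be told apart from the scatter: the same change on two cores in this assay, a 1.0-fold lower number (0.01 log units; within the scatter) from compound 2 to compound 1 and a 1.0-fold lower number (0.01 log units; within the scatter) from compound 3 to compound 4, 1.0-fold (0.00 log units) apart, within the scatter of two such steps. For the compounds shown here, this shows only that the swap makes no visible difference on these two cores in this one cell assay; two flat steps cannot show that a step of real size would carry over too, or that any other core would behave alike.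

The compounds shown leave open whether an amine or a carboxylic acid in the same place would move the number. Going by these compounds, whether such a group would act alike on both cores is also open.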